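The compounds below may be only part of what the source reports. "The series", "measured", "known", "first", "only" and "open" are said of these compounds alone.

- compound 1 `COc1cc(CN(CC(C)C)C(CC(=O)O)c2ccc(Cl)cc2)ccc1OCCN1C(=O)CCC1=O` at 80%
- compound 2 `COc1cc(CN(CC(C)C)C(CC(=O)O)c2ccc(Cl)c(Cl)c2)ccc1OCCN1C(=O)CCC1=O` at 75%

Going by the values given here, in an ADME assay on liver (Homo sapiens) for metabolic stability, read by LC-MS, using microsomes and NADPH (on this read-out higher numbers stand for a more stable compound and lower numbers for a less stable compound), compound 2 stands at 75% within the scatter of compound 1, the only other measured compound. The change to compound 3 `COc1cc(CN(CC(C)C)C(CC(=O)O)c2ccc(Cl)c(F)c2)ccc1OCCN1C(=O)CCC1=O` is fluoro in place of chloro on an aromatic carbon and amounts to fluoro in place of chloro on an aromatic carbon, ortho to a chloro group, or 3,4-dichlorophenyl to 4-chloro-3-fluorophenyl. Among the compounds with values here, one measured step bears on this: a number 5 percentage points lower from compound 1 to compound 2 (within the scatter) with chloro in place of hydrogen on an aromatic carbon. No step beyond the scatter is therefore expected, and the estimated a number 3 percentage points higher from compound 2 to compound 3 (within the scatter) in this assay reflects that. For compound 3 the expected value is 78% with an estimated range from 67% to 88% on this read-out.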

Compound 3, percent of the compound remaining: 76%
Estimate against measurement, compound 3: 2 percentage points above; the range from low to high includes it.
By their numbers in this assay, from the lowest: compounds 2, 3 and 1 (each within the scatter of the next).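

In this assay, fluoro in place of chloro, ortho to a chloro group, gives a number 1 percentage points higher from compound 2 to compound 3 (within the scatter), so 3,4-dichlorophenyl and 4-chloro-3-fluorophenyl cannot be told apart on this read-out. Fluoro in place of hydrogen gives a number 4 percentage points lower from compound 1 to compound 3 (within the scatter), so neither halogen has yet produced a step beyond the scatter at this position. Nothing measured here offers an explanation for these results. Going by these compounds, it remains open whether another group at this place, such as a nitrile or an amine, would give a step beyond the scatter.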